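Replacing a side chain with hydrogen

The compounds below may be only part of what the source reports. "The series", "measured", "known", "first", "only" and "open" are said of these compounds alone.

Values in a functional assay on MCF7 cells (Homo sapiens) for inhibition, read by MTT assay, with a stated time of 24 h (on this read-out higher numbers stand for weaker inhibition and lower numbers for stronger inhibition), each a limit and not a number:
compound 1 `CCOC1c2cc(OCc3cc(C)cc(C)c3)c(OCc3cc(C)cc(C)c3)cc2CCN1C(=O)OC(C)(C)C`: > 20000 nM
compound 2 `C/C=C/C(=O)CC1c2cc(OCc3cc(C)cc(C)c3)c(OCc3cc(C)cc(C)c3)cc2CCN1C(=O)OC(C)(C)C`: > 20000 nM
compound 3 `CC[C@@H]1C[C@H](O)C/C=C(/C)[C@H]2c3cc(OCc4ccccc4)c(OCc4ccccc4)cc3CCN12`: > 20000 nM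

Compound 2 stands at > 20000 nM, which is a limit of the assay. The whole record so far is the limit of > 20000 nM in this assay, at which 3 of the 3 values shown sit.

Compound 4 `Cc1cc(C)cc(COc2cc3c(cc2OCc2cc(C)cc(C)c2)CN(C(=O)OC(C)(C)C)CC3)c1` comes from compound 2 by a single change: hydrogen in place of ((prop-1-en-1-yl)carbonyl)methyl on a saturated ring carbon. In words, hydrogen takes the place of ((prop-1-en-1-yl)carbonyl)methyl on a saturated ring carbon.

Going by the values given here, only one measured step touches this carbon: a step that the two limits leave unreadable from compound 1 to compound 2. Its size cannot be read, so it offers no size or direction to carry over. The limit of compound 2, > 20000 nM, is therefore the only anchor for an expectation.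

No step beyond the usual scatter is expected in this assay, in either direction, and the estimated step is a step that the limit leaves unreadable from compound 2 to compound 4. For compound 4 the estimate is 30000 nM, with an expected range from 10000 nM to 80000 nM.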

Compound 4, half-maximal inhibitory concentration: > 20000 nM
Compound 4 ended at the assay's limit; the forecaster's own chance of this, stated with the estimate: 85%; the middle value does not contradict the limit.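

Compound 1, compound 2 and compound 4 all sit at a limit of the assay rather than at a number, so no step among them can be read: the limit of > 20000 nM in this assay, at which 4 of the 4 values shown sit.

The compounds shown leave open whether ethoxy, ((prop-1-en-1-yl)carbonyl)methyl or hydrogen on this saturated ring carbon makes any difference in this assay.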